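The source may hold more compounds than are shown below. What is called first, only, known or untested is meant among the compounds shown, and "the series" means these compounds.

Compounds measured so far in a functional assay on HeLa cells (Homo sapiens) for cytotoxicity, read by MTT assay, with a stated time of 48 h; a higher number here means a weaker inhibitor, a lower number a stronger inhibitor:
- Compound 1, `CCN(CC)c1ccc2cc(C(=O)c3ccc(N4CCN(C(=O)CN5CCN(S(=O)(=O)C6CC6)CC5)CC4)cc3)oc2c1`: 28100 nM
- Compound 2, `CCN(CC)c1ccc2cc(C(=O)c3ccc(N4CCN(C(=O)CN5CCN(Cc6ccc(/C=C/C(=O)OC)cc6)CC5)CC4)cc3)oc2c1`: 3040 nM
- Compound 3, `CCOC(=O)CN1CCN(CC(=O)N2CCN(c3ccc(C(=O)c4cc5ccc(N(CC)CC)cc5o4)cc3)CC2)CC1`: 22100 nM

Among the three, compound 1 gives the highest number, though its gap to compound 3, a 1.3-fold lower number from compound 1 to compound 3 (0.10 log units; within the scatter), stays within the scatter; only compound 2 stands clearly apart from it, as the step of a 7.3-fold higher number from compound 2 to compound 3 (0.86 log units; beyond the scatter) also shows from the other side.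

Compound 4, `CCN(CC)c1ccc2cc(C(=O)c3ccc(N4CCN(C(=O)CN5CCN(CC(C)=O)CC5)CC4)cc3)oc2c1`, has not yet been measured. It differs from compound 1 in one place: 2-oxopropyl in place of cyclopropylsulfonyl on an amine nitrogen in a ring. Within the data shown here, the step that bears on this is the one from compound 1 to compound 3, where another group with a carbonyl took the place of the cyclopropylsulfonyl on the same ring nitrogen and the number barely moved, a 1.3-fold lower number from compound 1 to compound 3 (0.10 log units; within the scatter). Among the measured compounds shown here, nothing among the measured compounds points to a large move here, and the change in compound 4 is of the same kind as that one. The expected step is therefore a 1.3-fold lower number from compound 1 to compound 4 (0.11 log units; within the scatter), small and without a firm direction. Compound 4 is estimated at 22000 nM, with a range from 9000 nM to 55000 nM.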

Compound 4, half-maximal inhibitory concentration: 2760 nM
Compound 4: the middle estimate sits 8.0-fold (0.90 log units) above what was measured; measured number below the stated range.
By their numbers in this assay, from the lowest: compounds 4 and 2 (each within the scatter of the next); then compounds 3 and 1 (each within the scatter of the next).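

At this amine nitrogen in a ring, the group matters in this assay: 2-oxopropyl in place of cyclopropylsulfonyl gives a 10-fold lower number from compound 1 to compound 4 (1.01 log units; beyond the scatter), so the flat step seen with (ethoxycarbonyl)methyl does not hold for every group with a carbonyl. A carbonyl at this place does not by itself set the number, as methyl in place of ethoxy on that carbonyl carbon gives an 8.0-fold lower number from compound 3 to compound 4 (0.90 log units; beyond the scatter). A phenyl-bearing group is also not needed to reach the level of compound 2, given a 1.1-fold lower number from compound 2 to compound 4 (0.04 log units; within the scatter). Nothing shown gives a reason for these steps.

On these data alone, it remains open whether a plain propyl or a 2-hydroxypropyl on this nitrogen would hold the number of compound 4. As far as these compounds go, how a longer ketone chain such as 2-oxobutyl would read in this assay is also open.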